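The source may report more compounds than this note shows. Statements on the series, on what has been measured and on what is new or still open speak of the compounds shown alone.

Among the compounds with values here, compound 1 `CCOC(=O)c1sc(-c2cccc(NC(=O)c3ccc(F)cc3)c2)nc1Nc1ccc(N2CCN(C)CC2)cc1` sits lowest of the three measured members in a functional assay on Raji cells (Homo sapiens) for antiproliferative activity, read by CCK-8 assay, with a stated time of 72 h, tested at 40 uM (on this read-out lower numbers stand for less inhibition and higher numbers for more inhibition at the one concentration tested (going by the name of the read-out)), where compound 1 gives 16.8%. Compound 2 `CCOC(=O)c1sc(-c2cccc(NC(=O)c3ccccc3)c2)nc1Nc1ccc(N2CCN(C)CC2)cc1` gives 42% in this assay, and compound 3 `CCOC(=O)c1sc(-c2cccc(NC(=O)c3ccccc3F)c2)nc1Nc1ccc(N2CCN(C)CC2)cc1` gives 89.8%. The two steps away from compound 1 are a number 25.2 percentage points higher from compound 1 to compound 2 (beyond the scatter) and a number 73 percentage points higher from compound 1 to compound 3 (beyond the scatter); between the other two measured compounds, a number 47.8 percentage points higher from compound 2 to compound 3 (beyond the scatter).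

Compound 4 `CCOC(=O)c1sc(-c2cccc(NC(=O)c3ccc(C#N)cc3)c2)nc1Nc1ccc(N2CCN(C)CC2)cc1` differs from compound 1 in one place: cyano in place of fluoro on an aromatic carbon. Within the data shown here, of the measured steps, only the one from compound 1 to compound 2 touches the same aromatic carbon, exchanging the fluoro there for hydrogen, and it gave a modest rise, a number 25.2 percentage points higher from compound 1 to compound 2 (beyond the scatter). The larger steps that involve compound 3 concern a different position of the benzoyl ring and do not bear on the present change. Among the measured compounds shown here, no measured compound carries a cyano group, so the direction of a cyano-for-fluoro exchange is not fixed by the numbers; the only anchor is that taking the fluoro away raised inhibition. A modest rise is therefore expected for compound 4, a number 23.2 percentage points higher from compound 1 to compound 4 (beyond the scatter), with wide uncertainty on either side. Compound 4 is estimated at 40% in this assay, within a range from 15% to 70%.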

Compound 4, a percentage reported as inhibition, at one concentration (the size of the read-out at that concentration, not a potency): 79.1%
The estimate for compound 4 lay 39.1 percentage points below the measured number; the measured number lies above the stated range.
By their numbers in this assay, from the lowest: compound 1; then compound 2; then compound 4; then compound 3.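

At the aromatic carbon para to a large group, the outcome in this assay depends strongly on which substituent is present: cyano in place of fluoro gives a number 62.3 percentage points higher from compound 1 to compound 4 (beyond the scatter), and cyano in place of hydrogen gives a number 37.1 percentage points higher from compound 2 to compound 4 (beyond the scatter). Among these three compounds the order at this carbon is therefore fluoro, then hydrogen, then cyano, so the low number of compound 1 reflects fluoro in particular and not the presence of any substituent there, while the hydrogen of compound 2 is not the best of the three. A change at this carbon also comes close to the high number reached with the 2-fluorophenyl amide, though a real gap remains, with a number 10.7 percentage points lower from compound 3 to compound 4 (beyond the scatter), and no supporting data are available to explain the split between fluoro and cyano at the same carbon.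

On these data alone, how an amino group or a carboxylic acid at this carbon would rank against hydrogen, fluoro and cyano remains open, as does the effect of a nitrile at the ring position that carries fluoro in compound 3. As far as these compounds go, all these readings come from a single concentration, so the order of potency also remains open.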